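A Shared Core, Three Limits, and a Fourth Aryl Group

The source may report more compounds than this note shows. Statements on the series, on what has been measured and on what is new or still open speak of the compounds shown alone.

Three compounds share one core and differ only in the aryl group carried on an aromatic nitrogen. Compound 1 `N#CC1=C(N)Oc2c(N)cc3nc4ccccc4nc3c2C12C(=O)N(Cc1cnnn1-c1cccc(C(F)(F)F)c1)c1ccccc12` bears a 3-(trifluoromethyl)phenyl there. In an ADME assay on HUVEC cells (Homo sapiens) for antiproliferative activity, read by MTT assay, with a stated time of 48 h (a lower number here means a stronger inhibitor, a higher number a weaker inhibitor), compound 1 reaches only the limit of the assay, > 50000 nM. Compound 2 `Cc1ccc(Cl)cc1-n1nncc1CN1C(=O)C2(C(C#N)=C(N)Oc3c(N)cc4nc5ccccc5nc4c32)c2ccccc21` carries a 5-chloro-2-methylphenyl instead; in this assay compound 2 likewise stops at the assay limit, > 50000 nM. Compound 3 `N#CC1=C(N)Oc2c(N)cc3nc4ccccc4nc3c2C12C(=O)N(Cc1cnnn1-c1ccc(F)c(Cl)c1)c1ccccc12` carries a 3-chloro-4-fluorophenyl, and in this assay compound 3 also gives only a limit, > 50000 nM. Because every value shown sits at the limit of > 50000 nM in this assay, at which 3 of the 3 values shown sit, none of the steps among them can be read: a step that the two limits leave unreadable from compound 1 to compound 2, a step that the two limits leave unreadable from compound 1 to compound 3, and a step that the two limits leave unreadable from compound 2 to compound 3. Compound 3 therefore stands at the assay limit alongside both others, with no ordering among the three.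

Compound 4 `Cc1cc(C)c(-n2nncc2CN2C(=O)C3(C(C#N)=C(N)Oc4c(N)cc5nc6ccccc6nc5c43)c3ccccc32)c(C)c1` is the next variation, with the change (2,4,6-trimethylphenyl in place of 3-chloro-4-fluorophenyl on an aromatic nitrogen). All three measured steps bear on this kind of exchange of the aryl group, and each was unreadable, so no shift in this assay beyond the scatter can be foreseen; the expectation is simply another limit. Compound 4 is thus estimated at 60000 nM, within 20000 nM to 200000 nM. The resulting step is expected to be a step that the limit leaves unreadable from compound 3 to compound 4.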

Compound 4, half-maximal inhibitory concentration: > 50000 nM
Compound 4: only a limit was reported; the forecaster's own chance of this, stated with the estimate: 85%; the middle value is on the limit's open side.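

In this assay compound 4 gives > 50000 nM, which is a limit and not a number. No step between compound 4 and compound 1, compound 2 or compound 3 can be read, because all four stop at the same limit: the limit of > 50000 nM in this assay, at which 4 of the 4 values shown sit.

Going by these compounds, whether the aryl group changes the activity of these four compounds at all stays open.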